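The source may hold more compounds than are shown below. What is called first, only, known or untested is meant among the compounds shown, and "the series" means these compounds.

Measured compounds:
Compound 1, `Cc1ccc(S(=O)(=O)Nc2cccc(-c3nc(-c4ccc(NC(=O)c5cccnc5)cc4Cl)no3)c2)cc1`, gives > 10000 nM in a functional assay on MDA-MB-231 cells (Homo sapiens) for antiproliferative activity, read by MTT assay, with a stated time of 72 h (on this read-out higher numbers stand for weaker inhibition and lower numbers for stronger inhibition), a limit of the assay.
Compound 2, `O=C(Nc1ccc(-c2noc(-c3cccc(NS(=O)(=O)c4ccc(C(F)(F)F)cc4)c3)n2)c(Cl)c1)c1cccnc1`, gives > 10000 nM in this assay, again a limit of the assay.

Among the measured compounds shown here, compound 1 therefore stands only at a limit in this assay, and the one further value shown is likewise a limit, so no number places it among the measured compounds. For the measured compounds named here, the single measured step, a step that the two limits leave unreadable from compound 1 to compound 2, puts trifluoromethyl in place of methyl on an aromatic carbon; its size cannot be read because both of its ends sit at the limit of > 10000 nM in this assay, at which 2 of the 2 values shown sit.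

The unmeasured compound 3, `COc1ccc(NC(=O)Nc2cccc(-c3nc(-c4ccc(NC(=O)c5cccnc5)cc4Cl)no3)c2)cc1`, differs from compound 1 by (4-methoxyphenyl)carbamoyl in place of (4-methylphenyl)sulfonyl on a nitrogen on an aromatic ring. Going by the values given here, no measured step touches this part of the shared core, so the one measured step bears on it only in showing that both neighbouring compounds remain at the limit. The step from compound 1 to compound 3 is expected to be a number no higher from compound 1 to compound 3 (the limit leaves the size open), which is no change beyond the scatter and most likely another limit. The estimate for compound 3 in this assay is 10000 nM, expected to lie between 2000 nM and 50000 nM.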

Compound 3, half-maximal inhibitory concentration: 3000 nM
Compound 3: the middle estimate sits 3.3-fold (0.52 log units) above what was measured, within the range that was stated.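

In this assay, among the compounds shown here, the nitrogen on the aromatic ring proves to be a place where a change yields a readable number, which the earlier compounds did not show: (4-methoxyphenyl)carbamoyl in place of (4-methylphenyl)sulfonyl gives an at least 3.3-fold lower number from compound 1 to compound 3 (0.52 log units; beyond the scatter). The step from methyl to trifluoromethyl on the sulfonyl side cannot be read, so compound 3 is the only compound shown that stands clear of the limit, and it does so with one hydrogen-bond donor that the leaving group lacks and one double bond fewer outside aromatic rings. The size of the step remains a minimum, since the sulfonyl compounds stay at the limit: the limit of > 10000 nM in this assay, at which 2 of the 3 values shown sit.

The change replaces the sulfonyl with a carbamoyl and the methyl with a methoxy in one move, so the compounds shown do not tell which of the two carries the step, and (4-methylphenyl)carbamoyl on the same nitrogen would separate them. They also leave open how other groups in this place would read, such as a plain acetyl or a (4-aminophenyl)carbamoyl.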